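The source may report more compounds than this note shows. Statements on the series, on what has been measured and on what is new or still open speak of the compounds shown alone.

Measured in a functional assay on the whole organism for antagonist activity, with Mus musculus as the target, in the maximal electroshock model; on this read-out higher numbers stand for an effect only at larger amounts of compound and lower numbers for an effect already at smaller amounts:

- Compound 1 `COC(=O)NC1=NC(c2ccccc2)CN1C`: 107 mg/kg
- Compound 2 `CCCOC(=O)NC1=NC(c2ccccc2F)CN1C`: 23 mg/kg
- Compound 3 `CC(C)OC(=O)NC1=NC(c2ccccc2F)CN1C`: 23 mg/kg

Compound 3, at 23 mg/kg, is level with compound 2, and together they hold the lowest of the three numbers. Compound 1 stands well apart from them with 107 mg/kg, but it differs from them in more than one place, so it cannot show what any single change does.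

The next compound is compound 4 `CC(C)OC(=O)NC1=NC(c2ccccc2Cl)CN1C`, with chloro in place of fluoro on an aromatic carbon.

Going by the values given here, the only measured single-place step, no change at the digits printed from compound 2 to compound 3 (within the scatter), puts isopropyl in place of propyl and leaves the fluoro untouched. It therefore bears on this swap only indirectly, showing that one small change in this series can leave the number unmoved. Among the compounds with values here, no measured pair exchanges fluoro for chloro, so the uncertainty is wide.

The expected change is small and within the scatter: a 1.1-fold higher number from compound 3 to compound 4 (0.04 log units; within the scatter).

For compound 4 the estimated value is 25 mg/kg, with an expected range of 10 mg/kg to 60 mg/kg.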

Compound 4, dose for half-maximal effect: 35 mg/kg
Compound 4: the middle estimate sits 1.4-fold (0.15 log units) below what was measured, within the range that was stated.
By their numbers in this assay, from the lowest: compounds 2, 3 and 4 (each within the scatter of the next); then compound 1.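

Chloro in place of fluoro, on an aromatic carbon ortho to a large group, gives a 1.5-fold higher number from compound 3 to compound 4 (0.18 log units; within the scatter) in this assay. Going by these compounds alone, this is the first measured change at this position, and it shows that the two halogens cannot be told apart here, whereas the earlier step changed only the group on the oxygen. Nothing available accounts for how either halogen acts at this position.

Still open, going by these compounds, is whether a methoxy group, a trifluoromethyl group or an amine on this aromatic carbon would keep the number at this level. Compound 1 differs from the others in more than one place, so the effect of plain hydrogen on this carbon also remains unsettled, as does whether chloro would read the same alongside the propyl chain of compound 2.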